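The source may hold more compounds than are shown below. What is called first, only, known or untested is meant among the compounds shown, and "the series" means these compounds.

Measured compounds:
Compound 1 `CC(C)C[C@H](N)CN(C(=O)[C@@H]1C[C@H]1c1ccccc1)c1ccc(-c2ccccc2)cc1`: 880 nM
Compound 2 `N[C@@H](CC1CCCCC1)CN(C(=O)[C@@H]1C[C@H]1c1ccccc1)c1ccc(-c2ccccc2)cc1`: 1.7 nM

Going by the values given here, in a functional assay for agonist activity at G protein-coupled receptor 88 (Homo sapiens), read by HTRF and cAMP accumulation (on this read-out higher numbers stand for an effect only at larger amounts of compound and lower numbers for an effect already at smaller amounts), compound 1 stands highest of the two numbers; the only measured step, a 520-fold lower number from compound 1 to compound 2 (2.71 log units; beyond the scatter), is large. Compound 3 `COc1ccccc1-c1ccc(N(C[C@@H](N)CC(C)C)C(=O)[C@@H]2C[C@H]2c2ccccc2)cc1` differs from compound 1 by methoxy in place of hydrogen on an aromatic carbon. The measured step concerns the saturated chain carbon, not the aromatic ring that compound 3 alters, so it offers no guide for this change. For compound 3 no step beyond the scatter is expected, and the expected step is no change at the digits printed from compound 1 to compound 3 (within the scatter). Compound 3 is accordingly estimated at 880 nM, with a range from 250 nM to 3000 nM.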

Compound 3, half-maximal effective concentration: 3200 nM
The estimate for compound 3 lay 3.6-fold (0.56 log units) below the measured number, and the stated range ends below it.
By their numbers in this assay, from the lowest: compound 2; then compound 1; then compound 3.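

In this assay, phenyl to 2-methoxyphenyl gives a 3.6-fold higher number from compound 1 to compound 3 (0.56 log units; beyond the scatter), so a change on this aromatic carbon, ortho to a large group, also moves the number. That step is modest beside a 520-fold lower number from compound 1 to compound 2 (2.71 log units; beyond the scatter), the change on the saturated chain carbon. No measurement shown accounts for the new step.

Going by these compounds, whether fluorine or hydroxyl on the same carbon would give a similar step remains open. So does whether methoxy would give a step of similar size on compound 2, which carries cyclohexyl.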